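Lengthening an Ethyl Chain on the Aziridinylquinone Core

The compounds below may be only part of what the source reports. "The series", "measured", "known", "first", "only" and "open" are said of these compounds alone.

Measured so far:
- compound 1 `CCCC1=C(N2CC2)C(=O)C(C(COC(N)=O)OC)=C(N2CC2)C1=O`: 5.07
- compound 2 `CCCC1=C(N2CC2)C(=O)C(CCC)=C(N2CC2)C1=O`: 4.44
- compound 3 `CCC1=C(N2CC2)C(=O)C(CCOC(N)=O)=C(N2CC2)C1=O`: 5.48

In a functional assay on L1210 cells (Mus musculus), with a stated time of 12 days (on this read-out higher numbers stand for higher potency (the scale is a negative logarithm) and lower numbers for lower potency), compound 3 gives the highest of the three numbers: compound 1 stands lower by a margin beyond the scatter, and compound 2 lower still. Compound 4 `CCCC1=C(N2CC2)C(=O)C(CCOC(N)=O)=C(N2CC2)C1=O` has not yet been measured. It differs from compound 3 in one place only: methyl in place of hydrogen on a saturated chain carbon, two bonds along the chain from a double-bonded ring carbon.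

Going by the values given here, none of the measured steps covers this exact change. Among the compounds with values here, the only step between measured neighbours, a number 0.63 log units lower from compound 1 to compound 2 (beyond the scatter), concerns a different substituent and says nothing about adding a single carbon to a short chain. Compounds 1 and 2 both carry the propyl chain that compound 4 would carry, but neither shares the rest of compound 3, so no clean comparison exists. A change of this size is expected to stay within the usual scatter, in either direction.

For compound 4 the expected value is 5.4, with a range from 4.9 to 5.9, corresponding to an expected step of a number 0.08 log units lower from compound 3 to compound 4 (within the scatter).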

Compound 4, logarithm of the reciprocal of the active concentration, log(1/C): 5.23
Estimate against measurement, compound 4: 0.17 log units above, within the range that was stated.
By their numbers in this assay, from the lowest: compound 2; then compounds 1, 4 and 3 (each within the scatter of the next, the first and the last beyond it).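

Methyl in place of hydrogen on this saturated chain carbon, which turns ethyl into propyl, gives a number 0.25 log units lower from compound 3 to compound 4 (within the scatter) and so shows that the longer chain is tolerated in this pair. Carbamoyloxy in place of methyl, on a saturated chain carbon two bonds along the chain from a double-bonded ring carbon, gives a number 0.79 log units higher from compound 2 to compound 4 (beyond the scatter) and so shows this group making a readable difference while the propyl chain stays the same. Hydrogen in place of methoxy, on a saturated chain carbon bound to a double-bonded ring carbon and a saturated chain carbon, gives a number 0.16 log units higher from compound 1 to compound 4 (within the scatter) and so shows no readable difference from removing that methoxy.

The compounds shown leave open whether a butyl chain or an amine at the propyl position would keep the number near that of compound 4. Nothing measured here gives a reason for any of these steps.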